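The compounds below may be only part of what the source reports. "The series", "measured", "known", "first", "only" and "open" are said of these compounds alone.

Measured so far:
Compound 1, `CCOC(=O)CC[C@H](NC(=O)CC[C@H](NC(=O)c1ccc(N(C)Cc2cnc3nc(N)nc(N)c3n2)cc1)C(=O)OCC)C(=O)OCC`, in a functional assay on CCRF-CEM cells (Homo sapiens) for inhibition (a lower number here means a stronger inhibitor, a higher number a weaker inhibitor), gives 1.8 ug/mL.
Compound 2, `CCOC(=O)CC[C@H](NC(=O)CC[C@H](NC(=O)c1ccc(N(C)Cc2cnc3nc(N)nc(N)c3n2)cc1)C(=O)N[C@@H](CCC(=O)OCC)C(=O)OCC)C(=O)OCC`, in this assay gives 3.8 ug/mL.

Compound 2 stands with the higher of the two numbers; compound 1 sits lower, and the gap between them is beyond the scatter.

Compound 3, `CCOC(=O)CC[C@H](NC(=O)CC[C@@H](NC(=O)c1ccc(N(C)Cc2cnc3nc(N)nc(N)c3n2)cc1)C(=O)N[C@@H](CCC(=O)OCC)C(=O)OCC)C(=O)OCC`, is not yet measured in this assay. It is related to compound 2 as follows: the two compounds have the same atoms and bonds and differ only in configuration as drawn: 1 of 3 stereo elements differ; a stereocentre at a saturated chain carbon is drawn S in compound 2 and R in compound 3. Among the compounds with values here, no step between measured compounds isolates a change of this kind, so nothing in the numbers at hand tells its size or direction. In this assay a change of configuration at one centre may move the number in either direction; a modest shift is expected, most likely toward a somewhat higher number, with compound 2 the point of reference. Compound 3 is therefore expected to give about 5 ug/mL, within 1.8 ug/mL to 15 ug/mL, a step of a 1.3-fold higher number from compound 2 to compound 3 (0.12 log units; within the scatter).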

Compound 3, concentration for 50% inhibition: 9 ug/mL
Compound 3: the middle estimate sits 1.8-fold (0.26 log units) below what was measured, and the stated range covers the measured number.
By their numbers in this assay, from the lowest: compound 1; then compound 2; then compound 3.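

In this assay the configuration at this saturated chain carbon now shows a readable effect: going from S to R gives a 2.4-fold higher number from compound 2 to compound 3 (0.37 log units; beyond the scatter). Of this pair, the S form as drawn, compound 2, is the stronger inhibitor, a direction that compounds 1 and 2 alone could not give. The step can be assigned to this single stereocentre because no atom or bond changes: the fact that compounds 2 and 3 differ only in the configuration as drawn.

As far as these compounds go, the size and direction of a change of configuration at the other two stereo elements remain open. From the compounds shown here alone, it is also open whether the preference for S at this carbon would persist with free carboxylic acids in place of the ethyl esters.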